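From 3-bromophenyl to 4-methoxyphenyl in compound 3

A few compounds are considered here, and "the series" means these few. Any claim that something is new, unique, unknown or untested is made for them only; others in the source may bear on it.

Three compounds built on a shared core have entries in a functional assay on SW480 cells (Homo sapiens) for cytotoxicity, read by sulforhodamine B assay, with a stated time of 48 h (on this read-out higher numbers stand for weaker inhibition and lower numbers for stronger inhibition), and a fourth still awaits its number. For compound 1 `COc1ccc(/C=C/C(=O)c2ccc(N)c(-c3ccc(F)cc3)c2)cc1O` the entry reads "not determined" (no result reported) and so it offers no comparison. Compound 2 `COc1ccc(/C=C/C(=O)c2cccc(-c3ccc(F)cc3)c2)cc1` gives 8350 nM in this assay and compound 3 `O=C(/C=C/c1cccc(Br)c1)c1cccc(-c2cccc(F)c2)c1` gives 8610 nM there. Compound 3 therefore stands level with compound 2, the gap between them lying within the usual scatter of repeated measurements.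

Compound 4 `COc1ccc(/C=C/C(=O)c2cccc(-c3cccc(F)c3)c2)cc1` differs from compound 3 by a single change, (4-methoxyphenyl in place of 3-bromophenyl on a double-bonded chain carbon bound to a double-bonded chain carbon), with 4-methoxyphenyl in place of 3-bromophenyl on a double-bonded chain carbon bound to a double-bonded chain carbon. Within the data shown here, no measured pair isolates this change. Among the measured compounds shown here, compound 2 also carries the 4-methoxyphenyl group and gives 8350 nM in this assay, a number level with that of compound 3, so the group has not yet been seen to separate the values. No shift beyond the scatter is therefore expected in this assay, in either direction. The expected size is a 1.1-fold lower number from compound 3 to compound 4 (0.03 log units; within the scatter) and this estimate stays within the scatter. For compound 4 the estimated value is 8000 nM, with an expected range from 3500 nM to 18000 nM.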

Compound 4, half-maximal inhibitory concentration: 4510 nM
The estimate for compound 4 lay 1.8-fold (0.25 log units) above the measured number; the measured number falls inside the stated range.
By their numbers in this assay, from the lowest: compounds 4, 2 and 3 (each within the scatter of the next).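

In this assay the exchange of 3-bromophenyl for 4-methoxyphenyl on a double-bonded chain carbon bound to a double-bonded chain carbon now has a pair of its own, and it gives a 1.9-fold lower number from compound 3 to compound 4 (0.28 log units; within the scatter) so that this position carries either group without a shift beyond the scatter. The entering group brings one hydrogen-bond acceptor that the leaving group lacks, yet the read-out does not separate the two. Compound 4 also opens a second single-place comparison, as 3-fluorophenyl in place of 4-fluorophenyl on an aromatic carbon gives a 1.9-fold lower number from compound 2 to compound 4 (0.27 log units; within the scatter) and so moving the fluorine likewise produces no change beyond the scatter. Nothing at hand bears on why these numbers sit where they do.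

On these data alone, whether a phenyl ring carrying a carboxylic acid or a morpholine at this chain carbon would move the number beyond the scatter remains open. Also open, as far as these compounds go, is whether the 3-fluorophenyl and 4-fluorophenyl groups would still read alike with 3-bromophenyl on the chain in place of 4-methoxyphenyl.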